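Second chloro on the benzyl group of a pyridinone

A few compounds are considered here, and "the series" means these few. Any claim that something is new, unique, unknown or untested is made for them only; others in the source may bear on it.

The three measured compounds share one core and differ only in the substituent on the benzyl group. Compound 1 `O=c1ccc(-c2ccc3cn[nH]c3c2)cn1Cc1cccc(C(F)(F)F)c1` gives 40 nM in an assay for inhibition of MAP kinase-interacting serine/threonine-protein kinase 1 (Homo sapiens), read by luminescence and ADP-Glo, with a stated time of 2 h (on this read-out lower numbers stand for stronger inhibition and higher numbers for weaker inhibition), compound 2 `O=c1ccc(-c2ccc3cn[nH]c3c2)cn1Cc1ccccc1` gives 315 nM, and compound 3 `O=c1ccc(-c2ccc3cn[nH]c3c2)cn1Cc1cccc(Cl)c1` gives 37 nM. Compound 3 holds the lowest number of the three, though the gap to compound 1 is within the scatter, while the gap to compound 2 is beyond it.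

Compound 4 `O=c1ccc(-c2ccc3cn[nH]c3c2)cn1Cc1ccc(Cl)c(Cl)c1` is not yet measured. It carries chloro in place of hydrogen on an aromatic carbon, so the benzyl group goes from 3-chlorophenyl to 3,4-dichlorophenyl. The step that bears most directly on this change is an 8.5-fold lower number from compound 2 to compound 3 (0.93 log units; beyond the scatter), where a first chloro entering for hydrogen produced a modest drop. The step of a 1.1-fold lower number from compound 1 to compound 3 (0.03 log units; within the scatter) shows that swapping one group for another of similar kind changed little. A second chloro may add less than the first did, so compound 4 is expected to show only a small step, a 1.5-fold lower number from compound 3 to compound 4 (0.17 log units; within the scatter), in the direction of a lower number. Compound 4 is therefore estimated at 25 nM, with a range from 10 nM to 80 nM.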

Compound 4, half-maximal inhibitory concentration: 62 nM
Beside the measured number, compound 4's estimate is 2.5-fold (0.39 log units) below it; measured number inside the range.
By their numbers in this assay, from the lowest: compounds 3, 1 and 4 (each within the scatter of the next); then compound 2.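

In this assay the carbon ortho to a chloro group and para to a large group accepts a second chloro with a 1.7-fold higher number from compound 3 to compound 4 (0.22 log units; within the scatter) and so gives no gain that can be told from the scatter, which the first chloro, with its clear step from the plain phenyl, did not foreshadow. The 3,4-dichlorophenyl group still stands apart from phenyl, with a 5.1-fold lower number from compound 2 to compound 4 (0.71 log units; beyond the scatter) showing that the advantage over the unsubstituted benzyl group survives the added chloro. No evidence on the cause of this result is at hand.

The compounds shown leave open whether a chloro on this carbon alone, without the first chloro, would also stand apart from compound 2. They also leave open how a methoxy group, a nitrile or an amine would fare on this same carbon.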